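Aromatic Ring in Place of Cyclohexyl at the Benzylic Carbon

The source may report more compounds than this note shows. Statements on the series, on what has been measured and on what is new or still open speak of the compounds shown alone.

Compound 2, `CN1CCC[C@@H]1Cn1nc(CC2CCCCC2)c2ccccc2c1=O`, carries a cyclohexyl group on the saturated chain carbon bound to an aromatic carbon of the shared core. In an assay for binding affinity to Alpha-1A adrenergic receptor (Homo sapiens) (on this read-out higher numbers stand for weaker inhibition and lower numbers for stronger inhibition), compound 2 gives only a limit, > 1990 nM, and not a number. The two other measured compounds carry aromatic groups at that position: compound 1, `O=c1c2ccccc2c(Cc2ccc(Cl)cc2)nn1CCNCCCCc1ccc(OCCCN2CCCCCC2)cc1`, gives 316 nM in this assay, and compound 3, `CN1CCCC1CCn1nc(Cc2ccc(Cl)cc2)c2ccccc2c1=O`, gives 316 nM. The limit of > 1990 nM in this assay, at which 1 of the 3 values shown sits, sets compound 2 apart from those two, and the saturated ring is the plainest structural difference between them. Compound 4, `COc1ccc(Cc2nn(C[C@H]3CCCN3C)c(=O)c3ccccc23)cc1`, has not yet been measured; it differs from compound 2 by 4-methoxyphenyl in place of cyclohexyl on a saturated chain carbon bound to an aromatic carbon. The aromatic ring in compound 4 brings it nearer to what compound 1 and compound 3 carry, although the substituent on that ring is different. Among the measured compounds shown here, with compound 2 known only as a limit, no measured step fixes the size of the change. The step of an at least 1.9-fold lower number from compound 2 to compound 4 (0.29 log units; that floor lies within the scatter) is expected to run toward stronger binding and beyond the scatter, by analogy with compound 1 at 316 nM and compound 3 at 316 nM. Compound 4 is therefore estimated at 1000 nM, with a range from 300 nM to 3000 nM.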

Compound 4, inhibition constant: 126 nM
For compound 4 the middle estimate is 7.9-fold (0.90 log units) above the measured one; the measured number lies below the stated range.
By their numbers in this assay, from the lowest: compound 4; then compounds 1 and 3 (each within the scatter of the next). At a limit, above all of these: compound 2.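

Among the compounds shown here, compound 2 and compound 4 are the first pair here that differ in one place, so this position now has a step of its own: with 4-methoxyphenyl in place of cyclohexyl on a saturated chain carbon bound to an aromatic carbon, this assay shows an at least 15-fold lower number from compound 2 to compound 4 (1.19 log units; beyond the scatter). Until now, any link between an aromatic group at this position and stronger binding rested on compounds that also differ from compound 2 elsewhere, whereas this pair shows it with the rest of the molecule unchanged. The printed size of the step is only a floor, since compound 2 is known solely as a limit: the limit of > 1990 nM in this assay, at which 1 of the 4 values shown sits.

The compounds shown leave open whether the step belongs to the aromatic ring itself or to the methoxy group on it, and a plain phenyl or a 4-hydroxyphenyl in the same place, with the rest of compound 4 kept, would separate the two. They also leave open how the read-out responds to a different link between that ring and the shared core, such as a longer chain in place of the single carbon.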